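Benzoyl-Indole Hydroxamic Acids Tested for Histone Deacetylase 8 Inhibition

The compounds below may be only part of what the source reports. "The series", "measured", "known", "first", "only" and "open" are said of these compounds alone.

Measured compounds:
compound 1, `COc1ccc(C(=O)c2ccc3c(ccn3S(=O)(=O)c3ccc(/C=C/C(=O)NO)cc3)c2)cc1`, 10000 nM
compound 2, `COc1ccc(C(=O)c2ccc3c(ccn3Cc3ccc(C(=O)NO)cc3)c2)cc1OC`, 756 nM
compound 3, `COc1cc(C(=O)c2ccc3c(ccn3Cc3ccc(C(=O)NO)cc3)c2)cc(OC)c1OC`, "not determined" (no result reported)

In an assay on isolated protein for inhibition of histone deacetylase 8 (Homo sapiens) (on this read-out lower numbers stand for stronger inhibition and higher numbers for weaker inhibition), compound 2 gives 756 nM, the lowest of the two numbers available. Its nearest neighbour is compound 1, whose 10000 nM lies well beyond the usual scatter. Compound 3 has no reported result.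

Compound 4, `O=C(NO)c1ccc(Cn2ccc3cc(C(=O)c4ccc(F)cc4)ccc32)cc1`, is not yet measured. It differs from compound 2 in one place: 4-fluorophenyl in place of 3,4-dimethoxyphenyl on a carbonyl carbon. For the measured compounds named here, no step between measured compounds covers this change, so the expectation rests on compound 2 alone, and the step of a 1.3-fold higher number from compound 2 to compound 4 (0.12 log units; within the scatter) is expected to be small, possibly within the scatter, with a slight lean toward weaker inhibition. Compound 4 is therefore estimated at 1000 nM, within a range from 300 nM to 3500 nM.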

Compound 4, half-maximal inhibitory concentration: 1240 nM
Compound 4: middle estimate off by 1.2-fold (0.09 log units), on the low side, within the range that was stated.
By their numbers in this assay, from the lowest: compounds 2 and 4 (each within the scatter of the next); then compound 1.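

In this assay, 4-fluorophenyl in place of 3,4-dimethoxyphenyl on a carbonyl carbon gives a 1.6-fold higher number from compound 2 to compound 4 (0.21 log units; within the scatter) and so leaves the inhibition unchanged within the scatter. This position therefore accepts a group that carries no hydrogen-bond acceptors as well as one that carries them, with no measurable loss. Nothing available bears on the reason for this result.

As far as these compounds go, what an amine or a carboxylic acid would do in place of 4-fluorophenyl on this carbonyl carbon stays open. So does whether this change would give a similar step on the core of compound 1.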